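The compounds below may be only part of what the source reports. "The series", "measured", "known", "first", "only" and "open" are said of these compounds alone.

Measured compounds:
compound 1, `COc1ccc(NC(=O)CSc2nc3ccc(OCC(F)(F)F)nc3[nH]2)cc1OC`, 61%
compound 2, `Cc1ccc(NC(=O)CSc2nc3cccnc3[nH]2)c(Cl)c1`, 2%

In an assay on isolated protein for inhibition of Ectonucleotide pyrophosphatase/phosphodiesterase family member 1 (Homo sapiens), tested at 10 uM (a higher number here means more inhibition at the concentration tested (going by the name of the read-out), a lower number less inhibition), compound 1 gives 61%, the highest of the two numbers. Compound 2 gives 2%, a gap beyond the scatter. Compound 3, `COc1ccc(NC(=O)CSc2nc3ccc(N4CCCCC4)nc3[nH]2)cc1OC`, has not yet been measured. It differs from compound 1 by piperidin-1-yl in place of 2,2,2-trifluoroethoxy on an aromatic carbon. For the measured compounds named here, no measured pair isolates this change, so the expectation rests on compound 1 alone, anchored by its 61%. A modest drop is expected, a number 11 percentage points lower from compound 1 to compound 3 (beyond the scatter), not clearly beyond the scatter. Compound 3 is estimated at 50%, with a range from 15% to 80%.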

Compound 3, a percentage reported as inhibition, at one concentration (the size of the read-out at that concentration, not a potency): 27%
For compound 3 the middle estimate is 23 percentage points above the measured one; measured number inside the range.
By their numbers in this assay, from the lowest: compound 2; then compound 3; then compound 1.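

In this assay, piperidin-1-yl in place of 2,2,2-trifluoroethoxy on this aromatic carbon, next to the ring nitrogen, gives a large step, a number 34 percentage points lower from compound 1 to compound 3 (beyond the scatter), which shows that inhibition depends on the group held here. The two groups match in heavy-atom count and in hydrogen-bond donors and acceptors, so those counts alone do not set the number at this position. Nothing available accounts for the step. Still open, from the compounds shown here alone, is where a methoxy group, a dimethylamino group or a morpholin-4-yl ring on the same carbon would fall relative to compound 1 and compound 3.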